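A step from compound 1 to compound 4

This account rests on a few compounds, and the source may have more. Where it says the series, first, only, none or still open, it means among the compounds named here.

- compound 1 (`COc1cc(-c2nn(-c3cccc(NC(=O)c4cccc(C(F)(F)F)c4)c3)cc2-c2ccncc2)ccc1Cl`) gives > 50000 nM as a limit
- compound 2 (`COc1cc(-c2nn(-c3cccc(NC(=O)Nc4ccc(Cl)c(Cl)c4)c3)cc2-c2ccncc2)ccc1Cl`) gives > 50000 nM as a limit
- compound 3 (`O=C(Nc1cccc(-n2cc(-c3ccncc3)c(-c3ccc(Cl)c(O)c3)n2)c1)Nc1cc(C(F)(F)F)cc(C(F)(F)F)c1`) gives 5010 nM as a number

In a functional assay on OVCAR-4 cells (Homo sapiens) for inhibition, read by sulforhodamine B assay, with a stated time of 48 h (on this read-out higher numbers stand for weaker inhibition of growth and lower numbers for stronger inhibition of growth), compound 1 stands at a limit, not at an exact number (> 50000 nM). Compound 4 (`COc1cc(-c2nn(-c3cccc(NC(=O)Nc4ccc(Cl)c(C(F)(F)F)c4)c3)cc2-c2ccncc2)ccc1Cl`) differs from compound 1 by one swap ((4-chloro-3-(trifluoromethyl)phenyl)amino in place of 3-(trifluoromethyl)phenyl on a carbonyl carbon): (4-chloro-3-(trifluoromethyl)phenyl)amino in place of 3-(trifluoromethyl)phenyl on a carbonyl carbon. Among the measured compounds shown here, one measured step bears on this swap (a step that the two limits leave unreadable from compound 1 to compound 2), and its size stays unknown. Only compound 3 gives a true number (5010 nM). For the measured compounds named here, no clear shift in either direction is expected, because the limit of > 50000 nM in this assay, at which 2 of the 3 values shown sit, and the one measured step gives no size. The expected step is therefore none that can be read (a number no higher from compound 1 to compound 4 (the limit leaves the size open)). Compound 4 is estimated at 50000 nM (expected range 10000 nM to 100000 nM).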

Compound 4, concentration for total growth inhibition: 25600 nM
The estimate for compound 4 lay 2.0-fold (0.29 log units) above the measured number; the measured number falls inside the stated range.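

In this assay, (4-chloro-3-(trifluoromethyl)phenyl)amino in place of 3-(trifluoromethyl)phenyl on a carbonyl carbon gives an at least 1.9-fold lower number from compound 1 to compound 4 (0.29 log units; that floor lies within the scatter). Trifluoromethyl in place of chloro on an aromatic carbon gives an at least 1.9-fold lower number from compound 2 to compound 4 (0.29 log units; that floor lies within the scatter). Compound 4 thus gives this series a true number at this position, yet each step starts from a limit and its full size stays unknown: the limit of > 50000 nM in this assay, at which 2 of the 4 values shown sit.

The compounds shown leave open how an amine or a carboxylic acid would fare in place of that chloro or trifluoromethyl.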